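Benzyl in Place of Isopropyl: One Expected Step

The source may hold more compounds than are shown below. What is called first, only, known or untested is meant among the compounds shown, and "the series" means these compounds.

Of the compounds shown here, two with a shared core have been tested in a functional assay (thoracic aorta, Rattus norvegicus, strain Wistar); a lower number here means that less compound is needed, a higher number that more compound is needed for the effect. Compound 1 `N#Cc1ccc(NC(=O)Nc2nc3ccc(Br)cc3s2)cc1` reaches only a limit in this assay, > 100000 nM, and so yields no number. Among the compounds with values here, compound 2 `CC(C)NC(=O)Nc1nc2ccc(Br)cc2s1` gives 22800 nM in this assay, the only number among the values shown. The other value is a limit: compound 1 sits at the limit of > 100000 nM in this assay, at which 1 of the 2 values shown sits.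

Compound 3 `O=C(NCc1ccccc1)Nc1nc2ccc(Br)cc2s1` has not yet been measured. It differs from compound 2 in one place, (benzyl in place of isopropyl on an amide-type nitrogen), that is, benzyl in place of isopropyl on an amide-type nitrogen. Within the data shown here, no measured pair shows what such a change does here, so the size of the step is open. The larger group is expected to cost a little: the step of a 1.3-fold higher number from compound 2 to compound 3 (0.12 log units; within the scatter) is estimated to lie close to the edge of the scatter, towards weaker. Compound 3 is expected to give 30000 nM in this assay. Its estimated range runs from 8000 nM to 120000 nM.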

Compound 3, half-maximal effective concentration: 64200 nM
Beside the measured number, compound 3's estimate is 2.1-fold (0.33 log units) below it; the measured number falls inside the stated range.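

In this assay the amide-type nitrogen turns out to be sensitive to the group it carries: benzyl in place of isopropyl gives a 2.8-fold higher number from compound 2 to compound 3 (0.45 log units; beyond the scatter) and so moves the number modestly towards weaker, beyond the scatter. The change brings in a six-membered aromatic ring of carbon only, and compound 3 still yields a number rather than a limit. Within the data shown here, compound 1 remains the one compound that gives only a limit and no number: the limit of > 100000 nM in this assay, at which 1 of the 3 values shown sits.

This single pair cannot separate the effect of the ring from that of the larger count of carbon atoms. From the compounds shown here alone, whether a methyl group, a cyclohexyl ring, or a longer chain such as phenethyl on this nitrogen would bring the number closer to that of compound 2 stays open.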